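The source may report more compounds than this note shows. Statements on the series, on what has been measured and on what is new or still open speak of the compounds shown alone.

Among the measured compounds shown here, compound 3, `CCOC(=O)CCCC/C=C(\c1ccccc1)c1cccnc1`, is the outlier among the three compounds measured so far in an assay (Equus caballus) for inhibition of Thromboxane-A synthase (Homo sapiens), using microsomes; on this read-out lower numbers stand for stronger inhibition and higher numbers for weaker inhibition. Compound 3 gives 600 nM, the highest of the three numbers. For the measured compounds named here, its nearest neighbour is compound 1, `COC(=O)CCCC/C=C(\c1ccccc1)c1cccnc1`, whose methyl ester gives 100 nM; the only single-point step on record, a 6.0-fold higher number from compound 1 to compound 3 (0.78 log units; beyond the scatter), is the exchange of methyl for hydrogen on a saturated chain carbon bound to an oxygen next to a carbonyl group. Further away stands compound 2, `O=C(O)CCCC/C=C(/c1ccc(Br)cc1)c1cccnc1`, which in this assay gives 82 nM; it differs from compound 1 in two places, so no single step connects it to the others.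

Compound 4, `CC(C)(CCCC/C=C(\c1ccccc1)c1cccnc1)C(=O)O`, takes a different route away from compound 3: 1-carboxy-1-methylethyl in place of ethoxycarbonyl on a saturated chain carbon, four bonds along the chain from a double-bonded chain carbon. Going by the values given here, no measured step covers this exact change. Among the compounds with values here, what bears on it is that the one ester-to-ester step, from compound 1 to compound 3, moved the number beyond the scatter, and that the only free acid measured, compound 2, sits at the low end of the range. A step back toward lower numbers is therefore expected, a 5.0-fold lower number from compound 3 to compound 4 (0.70 log units; beyond the scatter), with the added methyls an open question. Compound 4 is expected to give about 120 nM, within 30 nM to 500 nM.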

Compound 4, half-maximal inhibitory concentration: 45 nM
Estimate against measurement, compound 4: 2.7-fold (0.43 log units) above, and the stated range covers the measured number.
By their numbers in this assay, from the lowest: compounds 4, 2 and 1 (each within the scatter of the next, the first and the last beyond it); then compound 3.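

In this assay, 1-carboxy-1-methylethyl in place of ethoxycarbonyl on a saturated chain carbon, four bonds along the chain from a double-bonded chain carbon, gives a 13-fold lower number from compound 3 to compound 4 (1.12 log units; beyond the scatter), the largest step recorded so far at this position. Set against the methyl ester, the corresponding exchange gives a 2.2-fold lower number from compound 1 to compound 4 (0.35 log units; beyond the scatter), so this group goes with a lower number than either ester, though by clearly different margins. Among the compounds shown here, the only earlier free acid, compound 2, differed from the esters in more than one place, so compound 4 supplies the first comparison of a carboxylic acid with esters on a single core, and it shows that this position accepts the acid together with its added methyls without a rise in the number.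

The compounds shown do not separate the contribution of the carboxylic acid from that of the added methyls, a question that the unbranched carboxylic acid and the methyl ester of the branched acid on the same core would address. No measurement shown here offers an explanation for these steps.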